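The compounds below may be only part of what the source reports. "The series", "measured", "known", "first", "only" and "open" are said of these compounds alone.

In a functional assay on MGC-803 cells (Homo sapiens) for inhibition, read by MTT assay, with a stated time of 72 h (a lower number here means a stronger inhibitor, a higher number a weaker inhibitor), three compounds have been measured so far.
Compound 1 `C#CCSc1nc(NCCC(C)C)c2ccncc2n1`: > 80000 nM, which is a limit of the assay and not a number.
Compound 2 `C#CCSc1nc(Nc2ccccc2Cl)c2ccncc2n1`: 27600 nM.
Compound 3 `C#CCSc1nc(Nc2ccc(O)cc2)c2ccncc2n1`: > 80000 nM, again a limit of the assay rather than a number.

Going by the values given here, compound 1 therefore stands at the limit of this assay, as does compound 3, and compound 2 is the only one with a measured number; the point at which two of the three values sit is the limit of > 80000 nM in this assay, at which 2 of the 3 values shown sit. The readable steps are an at least 2.8-fold lower number from compound 1 to compound 2 (0.46 log units; beyond the scatter) and an at least 2.8-fold higher number from compound 2 to compound 3 (0.46 log units; beyond the scatter), whereas a step that the two limits leave unreadable from compound 1 to compound 3.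

Compound 4 `C#CCSc1nc(N2CCN(C)CC2)c2ccncc2n1` has not yet been measured. It differs from compound 1 by 4-methylpiperazin-1-yl in place of isopentylamino on an aromatic carbon. Among the compounds with values here, none of the measured steps bears directly on this change: each of them puts an aryl group on the nitrogen, while the change to compound 4 removes the nitrogen-bound hydrogen and brings in a non-aromatic ring. Within the data shown here, with compound 1 at the limit and compound 2 the only number, the weight of the data lies at the weak end. Compound 4 is therefore expected to give about 60000 nM, between 20000 nM and 160000 nM, and the estimated step from compound 1 is an at least 1.3-fold lower number from compound 1 to compound 4 (0.12 log units; that floor lies within the scatter).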

Compound 4, half-maximal inhibitory concentration: > 80000 nM
Compound 4: no number, only a limit; the forecaster's own chance of this, stated with the estimate: 60%; at least 1.3-fold (0.12 log units) between middle value and limit.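

Compound 4 gives > 80000 nM as a limit of the assay and not a number. Compound 1 also stands at a limit, so the step between them cannot be read: the limit of > 80000 nM in this assay, at which 3 of the 4 values shown sit.

The compounds shown leave open whether 4-methylpiperazin-1-yl and isopentylamino differ at all on the shared core.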